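This account rests on a few compounds, and the source may have more. Where it says the series, first, only, none or still open, it means among the compounds named here.

Measured so far:
- compound 1, `COCOc1ccc(C(=O)/C=C/c2ccc(OCOC)c(CC=C(C)C)c2)c(O)c1`: in an assay on isolated protein for inhibition of Aromatase (Homo sapiens) (a lower number here means a stronger inhibitor, a higher number a weaker inhibitor), compound 1 gives > 242000 nM, which is a limit of the assay.
- compound 2, `CC(C)=CCc1cc(/C=C/C(=O)c2ccc(O)cc2O)ccc1O`: in this assay compound 2 gives > 308000 nM, which is also a limit of the assay.

Among the measured compounds shown here, compound 1 thus has no number to stand on: its value is a limit (the limit of > 242000 nM in this assay, at which 1 of the 2 values shown sits), and the one other value shown, that of compound 2, is a limit as well (the limit of > 308000 nM in this assay, at which 1 of the 2 values shown sits). With two limits and no numbers, no step between measured compounds can be sized, and nothing in the shown data separates compound 1 from compound 2.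

Compound 3, `COCOc1ccc(C(=O)/C=C/c2ccc(OC)c(CC=C(C)C)c2)c(O)c1`, is to be measured in this assay. It differs from compound 1 by hydrogen in place of methoxy on a saturated chain carbon bound to an oxygen on an aromatic ring, so that a methoxymethoxy group becomes a methoxy group while the rest of compound 1 is kept.

For the measured compounds named here, since the only guide is a pair of limits, no step beyond the usual scatter is expected in either direction. The expected step that the limit leaves unreadable from compound 1 to compound 3 is effectively none. For compound 3 in this assay the estimate is 250000 nM, with a range from 50000 nM to 1000000 nM. It is expected that compound 3 will most likely again return only a limit rather than a number.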

Compound 3, half-maximal inhibitory concentration: > 261000 nM
Compound 3 ended at the assay's limit (the forecaster's own chance of this, stated with the estimate: 80%); at least 1.0-fold (0.01 log units) between middle value and limit.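

In this assay compound 3 gives > 261000 nM, which is a limit of the assay. Among the compounds shown here, compound 1 also stands only at a limit, so no step from compound 1 to compound 3 can be read. The compounds shown leave open what effect, if any, the change from methoxymethoxy to methoxy has on inhibition in this assay.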